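Halogenated benzyl variants of the triazole ether series

This account rests on a few compounds, and the source may have more. Where it says the series, first, only, none or still open, it means among the compounds named here.

Compound 3 `O=c1ccoc2cc(OCc3cn(Cc4cccc(Br)c4)nn3)ccc12` is one of two members of the set that give only a limit. In a functional assay on SW480 cells (Homo sapiens) for cytotoxicity, read by MTT assay, with a stated time of 48 h (a lower number here means a stronger inhibitor, a higher number a weaker inhibitor), compound 3 returns > 100000 nM, which is a limit of the assay and not a number. Compound 2 `N#Cc1ccc(Cn2cc(COc3ccc4c(=O)ccoc4c3)nn2)cc1` also sits at the limit, giving > 100000 nM in this assay. Among the measured compounds shown here, compound 1 `Cc1ccc(Cn2cc(COc3ccc4c(=O)ccoc4c3)nn2)cc1` is the only member with a number, 10400 nM in this assay. The step of an at least 9.6-fold higher number from compound 1 to compound 3 (0.98 log units; beyond the scatter) shows how far a change in the benzyl group can move the read-out, while a step that the two limits leave unreadable from compound 2 to compound 3 cannot be sized because both ends sit at the limit of > 100000 nM in this assay, at which 2 of the 3 values shown sit. Compound 4 `O=c1ccoc2cc(OCc3cn(Cc4ccc(Cl)cc4)nn3)ccc12` differs from compound 3 by 4-chlorophenyl in place of 3-bromophenyl on a saturated chain carbon bound to an aromatic nitrogen. For the measured compounds named here, only the step from compound 1 bears on this change, and its direction for the new group is open. The step expected is an at least 1.6-fold lower number from compound 3 to compound 4 (0.22 log units; that floor lies within the scatter). Compound 4 is estimated at 60000 nM, expected to lie between 10000 nM and 200000 nM.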

Compound 4, half-maximal inhibitory concentration: > 100000 nM
Compound 4 ended at the assay's limit; the forecaster's own chance of this, stated with the estimate: 50%; at least 1.6-fold (0.22 log units) between middle value and limit.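

In this assay, swapping the methyl for a chloro gives an at least 9.6-fold higher number from compound 1 to compound 4 (0.98 log units; beyond the scatter), so the 4-chlorophenyl of compound 4, like the 4-cyanophenyl of compound 2, does not keep the number seen with compound 1. Of the groups shown, only the 4-methylphenyl of compound 1 gives a number. The steps among compound 2, compound 3 and compound 4 cannot be read, and the set now gathers at one limit: the limit of > 100000 nM in this assay, at which 3 of the 4 values shown sit.

From the compounds shown here alone, whether these three groups differ from one another stays open. Also open, going by these compounds, is whether an ethyl or a methoxy in place of the methyl of compound 1 would keep a measurable number.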